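A few compounds are considered here, and "the series" means these few. Any claim that something is new, unique, unknown or untested is made for them only; others in the source may bear on it.

Compound 3 `CCCC(C)(O)CC(=O)O[C@H](CC=C(C)C)C1=CC(=O)c2c(O)ccc(O)c2C1=O` holds the lowest of the two numbers available in a functional assay on HeLa cells (Homo sapiens) for cytotoxicity, read by MTT assay (a lower number here means a stronger inhibitor, a higher number a weaker inhibitor), giving 72000 nM. Compound 2 `CC(C)=CC[C@@H](OC(=O)c1ccco1)C1=CC(=O)c2c(O)ccc(O)c2C1=O` gives 80300 nM, and the step of a 1.1-fold lower number from compound 2 to compound 3 (0.05 log units; within the scatter) lies within the scatter. Compound 1 `CC(C)=CC[C@@H](OC(=O)C1CCCCO1)C1=CC(=O)c2c(O)ccc(O)c2C1=O` is reported in this assay only as a limit, > 100000 nM. Because of the limit of > 100000 nM in this assay, at which 1 of the 3 values shown sits, the steps of an at least 1.2-fold lower number from compound 1 to compound 2 (0.09 log units; that floor lies within the scatter) and an at least 1.3-fold lower number from compound 1 to compound 3 (0.14 log units; that floor lies within the scatter) are floors only, both within the scatter. Compound 4 `CC(C)=CC[C@@H](OC(=O)CC(O)c1ccccc1)C1=CC(=O)c2c(O)ccc(O)c2C1=O` differs from compound 3 in the ester side chain: hydroxy(phenyl)methyl in place of 1-hydroxy-1-methylbutyl on a saturated chain carbon bound to a carbonyl carbon. Every measured step changes the group on the carbonyl carbon, and none leaves the scatter, so for compound 4 no step beyond the scatter is expected in this assay, a 1.0-fold lower number from compound 3 to compound 4 (0.01 log units; within the scatter). Compound 4 is therefore estimated at 70000 nM, with a range from 30000 nM to 150000 nM.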

Compound 4, half-maximal inhibitory concentration: 44500 nM
Beside the measured number, compound 4's estimate is 1.6-fold (0.20 log units) above it, and the stated range covers the measured number.
By their numbers in this assay, from the lowest: compounds 4, 3 and 2 (each within the scatter of the next). At a limit, above all of these: compound 1.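

Compound 1 is reported only as a limit, > 100000 nM. In this assay, 2-hydroxy-2-phenylethyl on the carbonyl carbon gives the first step in the series beyond the scatter, an at least 2.2-fold lower number from compound 1 to compound 4 (0.35 log units; beyond the scatter), though this is a floor only: the limit of > 100000 nM in this assay, at which 1 of the 4 values shown sits.
The other new steps, a 1.6-fold lower number from compound 3 to compound 4 (0.21 log units; within the scatter) and a 1.8-fold lower number from compound 2 to compound 4 (0.26 log units; within the scatter), stay within the scatter, so the aromatic ring separates compound 4 from neither compound 2 nor compound 3.

Open, as far as these compounds go, is whether the hydroxyl on the 2-hydroxy-2-phenylethyl chain matters to the number. Also open, from the compounds shown here alone, is how an amine or a carboxylic acid at this place would read.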